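Working notes on the step from compound 1 to compound 3

The compounds below may be only part of what the source reports. "The series", "measured", "known", "first", "only" and "open" are said of these compounds alone.

Compound 1 `CCS(=O)(=O)Nc1ccc2c(c1)/C(=C(/Nc1ccc(C)cc1)c1ccccc1)C(=O)N2` stands at the higher end of the two numbers gathered so far: in an ADME assay on HepG2 cells (Homo sapiens) for cytotoxicity, read by MTT assay, with a stated time of 48 h (on this read-out lower numbers stand for higher toxicity in this test and higher numbers for lower toxicity in this test), compound 1 gives 3.1 uM, whereas compound 2 `CS(=O)(=O)Nc1ccc2c(c1)/C(=C(/Nc1ccc(CN3CCCCC3)cc1)c1ccccc1)C(=O)N2` gives 0.2 uM in this assay, a gap beyond the scatter. These two differ in more than one place, so only their values are set side by side. Compound 3 `CCS(=O)(=O)Nc1ccc2c(c1)/C(=C(/NC1CCN(C)CC1)c1ccccc1)C(=O)N2` carries 1-methylpiperidin-4-yl in place of 4-methylphenyl on an amine nitrogen. Going by the values given here, no measured pair shows this change, so the step from compound 1 to compound 3 is expected to stay within the scatter, a 1.2-fold lower number from compound 1 to compound 3 (0.09 log units; within the scatter), with no firm direction. Compound 3 is accordingly estimated at 2.5 uM in this assay, within 0.7 uM to 10 uM.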

Compound 3, half-maximal toxic concentration: > 10 uM
Compound 3: no number, only a limit; the forecaster's own chance of this, stated with the estimate: 10%; at least 4.0-fold (0.60 log units) between middle value and limit.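

In this assay compound 3 gives > 10 uM, which is a limit of the assay and not a number. At this place, on an amine nitrogen, 1-methylpiperidin-4-yl in place of 4-methylphenyl gives an at least 3.2-fold higher number from compound 1 to compound 3 (0.50 log units; beyond the scatter), so this position does respond to the change. The size of the step is bounded only by the limit: the limit of > 10 uM in this assay, at which 1 of the 3 values shown sits.

Still open, going by these compounds, is how far compound 3 stands past its limit. Also open, on these data alone, is whether the ring nitrogen or the non-aromatic ring goes with the higher number: a cyclohexyl or a pyridin-4-yl group on the same amine nitrogen would separate the two.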